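Swapping Cyano for (Dimethylamino)methyl on a Chain

This account rests on a few compounds, and the source may have more. Where it says the series, first, only, none or still open, it means among the compounds named here.

- compound 1 `C=CCn1c(=O)c2[nH]cnc2n(CCC)c1=O` gives 1600 nM
- compound 2 `CCCn1c(=O)n(CCC#N)c(=O)c2[nH]cnc21` gives 1700 nM
- compound 3 `CCCn1c(=O)n(CCCN(C)C)c(=O)c2[nH]cnc21` is not yet measured

So far the two measured compounds sit level in a functional assay (trachea) with Cavia porcellus as the target (on this read-out lower numbers stand for an effect already at smaller amounts and higher numbers for an effect only at larger amounts of compound), and neither ranks above the other. Among the measured compounds shown here, the only measured step is a 1.1-fold higher number from compound 1 to compound 2 (0.03 log units; within the scatter) and it is the sole guide here.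

Compound 3 differs from compound 2 at the end of a chain: (dimethylamino)methyl in place of cyano on a saturated chain carbon, two bonds along the chain from an aromatic nitrogen with (dimethylamino)methyl in place of cyano on a saturated chain carbon, two bonds along the chain from an aromatic nitrogen.

Neither measured compound carries a dimethylamino group, so this guide is weak. Starting from compound 2 at 1700 nM no step beyond the scatter is expected in this assay and no firm direction can be given. The estimate means a 1.2-fold higher number from compound 2 to compound 3 (0.07 log units; within the scatter) as the expected step, with a wide margin. For compound 3 the estimate is 2000 nM with 500 nM to 8000 nM as the expected range.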

Compound 3, half-maximal effective concentration: 20500 nM
Beside the measured number, compound 3's estimate is 10-fold (1.01 log units) below it; the measured number lies above the stated range.
By their numbers in this assay, from the lowest: compounds 1 and 2 (each within the scatter of the next); then compound 3.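

In this assay, this place on the chain proved sensitive to the group it carries: (dimethylamino)methyl in place of cyano gives a 12-fold higher number from compound 2 to compound 3 (1.08 log units; beyond the scatter), whereas the earlier change from vinyl to cyanomethyl stayed within the scatter. Measured against the vinyl compound, 2-(dimethylamino)ethyl in place of vinyl gives a 13-fold higher number from compound 1 to compound 3 (1.11 log units; beyond the scatter), so compound 3 needs clearly larger amounts for its effect than either earlier compound. Nothing available explains this rise.

The compounds shown do not separate the role of the dimethylamino group from that of the longer chain that carries it. From the compounds shown here alone, how a plain pentyl chain, a primary amine or a carboxylic acid would compare at this place remains open.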